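Exchanging piperidinyl for dimethylamino on a shared bridged core

The source may report more compounds than this note shows. Statements on the series, on what has been measured and on what is new or still open speak of the compounds shown alone.

Measured compounds:
Compound 1, `CCN(CC)CC(=O)OC1CC2(N(C)C)CC(c3ccccc3)C1C(c1ccccc1)C2`: 30100 nM
Compound 2, `CCN(CC)CC(=O)OC1CC2(N3CCCCC3)CC(c3ccccc3)C1C(c1ccccc1)C2`: 23900 nM
Compound 3, `NC1CC2(N3CCCCC3)CC(c3ccccc3)C1C(c1ccccc1)C2`: 35000 nM

Of the compounds shown here, three have been measured in an ADME assay on L6 cells (Rattus norvegicus) for cytotoxicity, read by resazurin assay, with a stated time of 72 h; on this read-out higher numbers stand for weaker inhibition and lower numbers for stronger inhibition. Compound 2 `CCN(CC)CC(=O)OC1CC2(N3CCCCC3)CC(c3ccccc3)C1C(c1ccccc1)C2` gives 23900 nM in this assay. Compound 1 `CCN(CC)CC(=O)OC1CC2(N(C)C)CC(c3ccccc3)C1C(c1ccccc1)C2` gives 30100 nM in this assay, and compound 3 `NC1CC2(N3CCCCC3)CC(c3ccccc3)C1C(c1ccccc1)C2` gives 35000 nM in this assay. All three numbers lie within the scatter of one another, so none is distinguished from the others.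

The change from compound 2 to compound 1 is dimethylamino in place of piperidin-1-yl on a saturated ring carbon. It produced a 1.3-fold higher number from compound 2 to compound 1 (0.10 log units; within the scatter).

Compound 4 `CN(C)C12CC(N)C(C(c3ccccc3)C1)C(c1ccccc1)C2` is not yet measured. It arises from compound 3 by dimethylamino in place of piperidin-1-yl on a saturated ring carbon. This is the same kind of change as that from compound 2 to compound 1, but not the same: around the place in compound 1 one of the two-bond ring neighbours bears a (((diethylamino)methyl)carbonyl)oxy group, while in compound 4 it bears an amino group. The two cores differ by amino in place of (((diethylamino)methyl)carbonyl)oxy on a saturated ring carbon.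

Within the data shown here, the step from compound 3 to compound 4 is expected to be a 1.2-fold higher number from compound 3 to compound 4 (0.09 log units; within the scatter), because a 1.3-fold higher number from compound 2 to compound 1 (0.10 log units; within the scatter) is the only precedent for this exchange and stayed within the scatter. Compound 4 is therefore estimated at 43000 nM in this assay, with a range from 20000 nM to 90000 nM.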

Compound 4, half-maximal inhibitory concentration: 40900 nM
Compound 4: the middle estimate sits 1.1-fold (0.02 log units) above what was measured, within the range that was stated.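

Dimethylamino in place of piperidin-1-yl, this time on the core that bears the amino group, gives a 1.2-fold higher number from compound 3 to compound 4 (0.07 log units; within the scatter) in this assay, and the two instances of this exchange agree: the same change on two cores in this assay, a 1.3-fold higher number (0.10 log units; within the scatter) from compound 2 to compound 1 and a 1.2-fold higher number (0.07 log units; within the scatter) from compound 3 to compound 4, 1.1-fold (0.03 log units) apart, within the scatter of two such steps. Amino in place of (((diethylamino)methyl)carbonyl)oxy, on the core that bears dimethylamino, gives a 1.4-fold higher number from compound 1 to compound 4 (0.13 log units; within the scatter), and this exchange also agrees across its two cores: the same change on two cores in this assay, a 1.5-fold higher number (0.17 log units; within the scatter) from compound 2 to compound 3 and a 1.4-fold higher number (0.13 log units; within the scatter) from compound 1 to compound 4, 1.1-fold (0.03 log units) apart, within the scatter of two such steps. This shows that on these two pairs of cores neither exchange produced a step that can be told from the scatter, and that the outcome on one core matched the outcome on the other; it does not show that either exchange has a real effect of a shared size, nor that the match would persist where a step rose beyond the scatter.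

The compounds shown leave open whether the same agreement would hold for other groups on that saturated ring carbon, such as pyrrolidin-1-yl or morpholin-4-yl, or for a carboxylic acid or a longer amine chain in place of the amino group. They also leave open whether these exchanges would behave alike on any core beyond the ones shown here.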